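Chloro for Methoxy on a PANC-1 Series

The source may report more compounds than this note shows. Statements on the series, on what has been measured and on what is new or still open speak of the compounds shown alone.

Measured compounds:
Compound 1, `COc1ccc(NC(=O)Oc2cc(=O)n(CCCO)c3c2CC(CC=C(C)C)C(C)(C)C3)cc1`: 0%
Compound 2, `CC(C)=CCC1Cc2c(OC(=O)Nc3ccc(Cl)cc3)cc(=O)n(CCCO)c2CC1(C)C`: 0%
Compound 3, `COc1ccc(OCCCOc2cc(=O)n(CCCO)c3c2CC(C/C=C(\C)CCC=C(C)C)C(C)(C)C3)cc1`: 0%

In a functional assay on PANC-1 cells (Homo sapiens) for inhibition, read by MTT assay, with a stated time of 24 h, tested at 10 uM (on this read-out higher numbers stand for more inhibition at the one concentration tested (going by the name of the read-out) and lower numbers for less inhibition), compound 1 gives 0% and compound 2 gives 0%. Among the measured compounds shown here, the single change between them is chloro in place of methoxy on an aromatic carbon, and the step of no change at the digits printed from compound 1 to compound 2 (within the scatter). Compound 3 gives 0%, level with both; the difference between its core and that of compound 1 is not broken down here. Compound 4, `CC(C)=CCC/C(C)=C/CC1Cc2c(OCCCOc3ccc(Cl)cc3)cc(=O)n(CCCO)c2CC1(C)C`, carries the same change relative to compound 3, namely (chloro in place of methoxy on an aromatic carbon), at a place described in the same words as before. Because no change at the digits printed from compound 1 to compound 2 (within the scatter) showed no movement, the same change is expected to produce a number 2 percentage points higher from compound 3 to compound 4 (within the scatter) in this assay. Compound 4 is therefore estimated at 2%, within 0% to 12%.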

Compound 4, a percentage reported as inhibition, at one concentration (the size of the read-out at that concentration, not a potency): 0%
The estimate for compound 4 lay 2 percentage points above the measured number, within the range that was stated.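

In this assay, chloro in place of methoxy on the aromatic carbon gives no change at the digits printed from compound 3 to compound 4 (within the scatter). Set beside the earlier step, the change reads the same on the two cores: the same change on two cores in this assay, no change at the digits printed (within the scatter) from compound 1 to compound 2 and no change at the digits printed (within the scatter) from compound 3 to compound 4, 0 percentage points apart, within the scatter of two such steps

Among the compounds shown here, all four compounds read the same value, however, so this agreement shows only that the change moved neither pair at this one concentration, not how it would carry over to a compound with measurable inhibition. The compounds shown leave open whether another group at this place, such as an amine or a carboxylic acid, would give a reading above that shared value in this assay. As far as these compounds go, whether a different link to the aromatic ring, such as an amide, would do so also remains open.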